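Aminophenyl for methylphenyl on the shared core

This account rests on a few compounds, and the source may have more. Where it says the series, first, only, none or still open, it means among the compounds named here.

Measured compounds:
compound 1 `Nc1ccc(-c2cc(Cl)cc(C(=O)Nc3nn[nH]n3)n2)cc1` — 100%
compound 2 `CCCOc1cc(C(=O)Nc2nn[nH]n2)nc(-c2ccc(N)cc2)c1` — 68%
compound 3 `Cc1cccc(-c2cc(C)cc(C(=O)Nc3nn[nH]n3)n2)c1` — 61%

In a functional assay on the whole organism with Rattus norvegicus as the target, at a dose of 3 mg/kg by the oral route (a higher number here means a stronger effect of the compound at the dose given, a lower number a weaker effect), compound 3 gives the lowest of the three numbers, within the scatter of compound 2 and beyond the scatter below compound 1. Compound 4 `Cc1cc(C(=O)Nc2nn[nH]n2)nc(-c2ccc(N)cc2)c1` differs from compound 3 in one place: 4-aminophenyl in place of 3-methylphenyl on an aromatic carbon. Within the data shown here, the only step measured, a number 32 percentage points lower from compound 1 to compound 2 (beyond the scatter), concerns a change on the core rather than on the phenyl group, so no measured step bears directly on this change. What is known is that compound 1 and compound 2, which both carry 4-aminophenyl, give the two higher numbers. Compound 4 is therefore expected to rise, with a step of a number 24 percentage points higher from compound 3 to compound 4 (beyond the scatter). The estimate for compound 4 is 85%, ranging from 55% to 100%.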

Compound 4, a percentage reported as inhibition, in the whole organism at one dose (the size of the read-out at that dose, not a potency): 100%
The estimate for compound 4 lay 15 percentage points below the measured number, within the range that was stated.
By their numbers in this assay, from the lowest: compounds 3 and 2 (each within the scatter of the next); then compounds 1 and 4 (each within the scatter of the next).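

In this assay, 4-aminophenyl in place of 3-methylphenyl gives a number 39 percentage points higher from compound 3 to compound 4 (beyond the scatter), the first step measured on this aromatic carbon next to the ring nitrogen. With 4-aminophenyl kept, methyl in place of propoxy gives a number 32 percentage points higher from compound 2 to compound 4 (beyond the scatter), while methyl in place of chloro gives no change at the digits printed from compound 1 to compound 4 (within the scatter), so methyl and chloro are not told apart here. No measurement shown accounts for these steps.

Still open, from the compounds shown here alone, is whether the amine or its place on the phenyl ring carries the step, a question that 3-aminophenyl and 4-methylphenyl would separate. Also open, going by these compounds, is how a methoxy or an ethyl group on the shared core would compare.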